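The source may hold more compounds than are shown below. What is called first, only, known or untested is meant among the compounds shown, and "the series" means these compounds.

Working notes on the series.

For the measured compounds named here, compound 1 `CN(C)CC[C@H](CSc1ccccc1)Nc1ccc(S(=O)(=O)NC(=O)c2ccc(N3CCN(Cc4ccccc4-c4ccc(Cl)cc4)CC3)cc2)cc1` is the weakest of the three measured members of this set: in a functional assay on NCI-H146 cells (Homo sapiens) for cytotoxicity, with a stated time of 48 h, in the presence of a further agent that is not named here (a lower number here means that less compound is needed, a higher number that more compound is needed for the effect), compound 1 gives 78700 nM, the highest number measured here. Compound 3 `O=C(NS(=O)(=O)c1ccc(NCCSc2ccccc2)c([N+](=O)[O-])c1)c1ccc(N2CCN(Cc3ccccc3-c3ccc(Cl)cc3)CC2)cc1` comes nearest, giving 33000 nM in this assay, a gap beyond the scatter. Compound 2 `CN(C)CC[C@H](CSc1ccccc1)Nc1ccc(S(=O)(=O)NC(=O)c2ccc(N3CCN(CC4=C(c5ccc(Cl)cc5)CCOC4)CC3)cc2)cc1[N+](=O)[O-]` lies furthest away, giving 266 nM in this assay. Going by the values given here, both compound 2 and compound 3 carry a nitro group on the aromatic ring bearing the sulfonamide, whereas compound 1 carries hydrogen there; compound 2 and compound 3 also differ from compound 1 elsewhere, so no single step between measured compounds is available.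

Compound 4 `CN(C)CC[C@H](CSc1ccccc1)Nc1ccc(S(=O)(=O)NC(=O)c2ccc(N3CCN(Cc4ccccc4-c4ccc(Cl)cc4)CC3)cc2)cc1C#N` introduces (cyano in place of hydrogen on an aromatic carbon). Among the compounds with values here, with no directly comparable pair in hand, the expectation rests on the observation that the two substituted members, compound 2 at 266 nM and compound 3 at 33000 nM, both sit well below compound 1. A sizeable drop in the number is therefore expected, with the step from compound 1 to compound 4 estimated as a 26-fold lower number from compound 1 to compound 4 (1.42 log units; beyond the scatter). Compound 4 is estimated at 3000 nM in this assay, within a range of 500 nM to 20000 nM.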

Compound 4, half-maximal effective concentration: 1930 nM
For compound 4 the middle estimate is 1.6-fold (0.19 log units) above the measured one; the measured number falls inside the stated range.
By their numbers in this assay, from the lowest: compound 2; then compound 4; then compound 3; then compound 1.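

Cyano in place of hydrogen on an aromatic carbon gives a 41-fold lower number from compound 1 to compound 4 (1.61 log units; beyond the scatter) in this assay and is the first change in the series that can be read at a single place. This position, ortho to a large group and meta to a large group, therefore responds strongly on its own, with none of the other differences carried by compound 2 and compound 3. No measurement in hand bears on what lies behind this step.

Going by these compounds, whether other groups here, such as an amine or a carboxylic acid, would move the number as far remains open. Nitro cannot be set against cyano at this position, as compound 2 and compound 3 each differ from compound 4 in other places too, so those steps cannot be read.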